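Trifluoromethylphenyl in place of dimethylphenyl: an expected value

The compounds below may be only part of what the source reports. "The series", "measured", "known", "first", "only" and "open" are said of these compounds alone.

Compound 1 `Cc1nc(-c2ccc(F)cc2)c(C(=O)N2CCN(c3cccc(Cl)c3)CC2)o1` gives 40.1 nM.
Compound 2 `Cc1nc(-c2ccccc2)c(C(=O)N2CCN(c3c(C)cccc3C)CC2)o1` gives 146 nM.
Compound 3 `Cc1ccc(C)c(N2CCN(C(=O)c3oc(C)nc3-c3ccc(F)cc3)CC2)c1` gives 358 nM.

All three were tested in a functional assay on HL-60 cells (Homo sapiens) for inhibition, read by MTT assay, with a stated time of 72 h; on this read-out lower numbers stand for stronger inhibition and higher numbers for weaker inhibition. Compound 2 stands second highest of the three, with compound 3 above it and compound 1 below it. Compound 4 `Cc1nc(-c2ccccc2)c(C(=O)N2CCN(c3ccccc3C(F)(F)F)CC2)o1` is not yet measured; it differs from compound 2 in 2-(trifluoromethyl)phenyl in place of 2,6-dimethylphenyl on an amine nitrogen in a ring. Among the measured compounds shown here, no measured step changes exactly this group. The nearest guide is an 8.9-fold higher number from compound 1 to compound 3 (0.95 log units; beyond the scatter), showing that exchanging the aryl group on that ring nitrogen can move the number modestly; compound 2 and compound 3, carrying two different dimethylphenyl groups, lie fairly close together. A step of similar or smaller size, without a clear direction, is therefore expected. Compound 4 is estimated at 150 nM, within 50 nM to 450 nM, an expected step of a 1.0-fold higher number from compound 2 to compound 4 (0.01 log units; within the scatter).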

Compound 4, half-maximal inhibitory concentration: 120 nM
For compound 4 the middle estimate is 1.3-fold (0.10 log units) above the measured one; the range from low to high includes it.
By their numbers in this assay, from the lowest: compound 1; then compounds 4 and 2 (each within the scatter of the next); then compound 3.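

In this assay there is a 1.2-fold lower number from compound 2 to compound 4 (0.09 log units; within the scatter) when 2-(trifluoromethyl)phenyl takes the place of 2,6-dimethylphenyl, so these two groups on the ring nitrogen cannot be told apart here. Set against an 8.9-fold higher number from compound 1 to compound 3 (0.95 log units; beyond the scatter) in the same assay, this shows that not every aryl exchange at this nitrogen moves the number beyond the scatter. Nothing shown points to a cause for this result. Still open, going by these compounds, is how a phenyl carrying a methoxy group or a nitrile would read at this nitrogen. On these data alone, it is also open whether 2-(trifluoromethyl)phenyl would read the same on the core of compound 1.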